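Amino for chloro on the fused ring

A few compounds are considered here, and "the series" means these few. Any claim that something is new, unique, unknown or untested is made for them only; others in the source may bear on it.

Within the data shown here, in a functional assay on EKVX cells (Homo sapiens) for antiproliferative activity, read by sulforhodamine B assay, with a stated time of 48 h (a higher number here means a weaker inhibitor of growth, a lower number a stronger inhibitor of growth), compound 2 `Nc1nn(C(=O)Nc2ccc(Cc3ccccc3)cc2)c2ccc(Cl)cc12` gives 3190 nM, the lowest of the two numbers so far, while compound 1 `Nc1nn(C(=O)Nc2ccc(Cc3ccccc3)cc2)c2ccccc12` gives 11200 nM. Among the measured compounds shown here, the only measured step is a 3.5-fold lower number from compound 1 to compound 2 (0.55 log units; beyond the scatter). Compound 3 `Nc1ccc2c(c1)c(N)nn2C(=O)Nc1ccc(Cc2ccccc2)cc1` differs from compound 2 by amino in place of chloro on an aromatic carbon. For the measured compounds named here, no measured pair exchanges chloro for amino, so the direction rests on weak ground; removing chloro is expected to give back part of the gain seen in this assay, so a step of a 2.2-fold higher number from compound 2 to compound 3 (0.34 log units; beyond the scatter) is expected for compound 3. The estimate for compound 3 is 7000 nM, within 2500 nM to 20000 nM.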

Compound 3, concentration for 50% growth inhibition: 14000 nM
Beside the measured number, compound 3's estimate is 2.0-fold (0.30 log units) below it; measured number inside the range.
By their numbers in this assay, from the lowest: compound 2; then compounds 1 and 3 (each within the scatter of the next).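

In this assay, amino on this aromatic carbon does not keep what chloro gained: the exchange gives a 4.4-fold higher number from compound 2 to compound 3 (0.64 log units; beyond the scatter) and so separates the two groups. Set against hydrogen, amino gives a 1.3-fold higher number from compound 1 to compound 3 (0.10 log units; within the scatter) and thus no gain, so the response at this position depends on the group placed there, not on substitution alone. Nothing at hand accounts for the gap between chloro and amino. As far as these compounds go, whether fluoro, bromo or methyl matches chloro here remains open. So does the result for a carboxylic acid or methoxy at this position.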